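A chloro group added beside nothing named: compound 1 to compound 3

The compounds below may be only part of what the source reports. "The series", "measured", "known", "first", "only" and "open" are said of these compounds alone.

Compound 1 `NCc1cccc(C2CCN(C(=O)c3ccc(O)c(O)c3)CC2)c1` was tested in an assay on isolated protein for inhibition of tryptase beta-2 (Mus musculus), with stated times of 3 h, 30 s and 15 min (on this read-out lower numbers stand for stronger inhibition and higher numbers for weaker inhibition), and gave 2310 nM. Among the compounds with values here, only one other measurement is in hand: compound 2 `NCc1cccc(C2CCN(C(=O)c3ccc(CO)c(O)c3)CC2)c1` gave 1550 nM in this assay. Within the data shown here, these two numbers sit within the usual scatter of each other, so compound 1 cannot be told apart from compound 2 on this read-out; the single step known, a 1.5-fold lower number from compound 1 to compound 2 (0.17 log units; within the scatter), is a swap of hydroxymethyl for hydroxy on an aromatic carbon and is too small to count.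

Compound 3 `NCc1cccc(C2CCN(C(=O)c3cc(O)c(O)c(Cl)c3)CC2)c1` differs from compound 1 at a different spot: chloro in place of hydrogen on an aromatic carbon. Among the measured compounds shown here, no measured step involves a chloro group, and the one step available, from compound 1 to compound 2, changes a different position and stays within the scatter. There is therefore no evidence for a shift in this assay in either direction, and the expected outcome for compound 3 is a number close to that of compound 1, with the step of a 1.2-fold lower number from compound 1 to compound 3 (0.06 log units; within the scatter) expected to stay inside the scatter. The estimate for compound 3 is 2000 nM, with a range from 700 nM to 6000 nM.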

Compound 3, half-maximal inhibitory concentration: 17500 nM
The estimate for compound 3 lay 8.8-fold (0.94 log units) below the measured number; measured number above the stated range.
By their numbers in this assay, from the lowest: compounds 2 and 1 (each within the scatter of the next); then compound 3.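

The position on the aromatic carbon that is ortho to a hydroxy group, meta to a hydroxy group and meta to a large group turns out to be sensitive in this series. In this assay, within the data shown here, the step of chloro in place of hydrogen is a 7.6-fold higher number from compound 1 to compound 3 (0.88 log units; beyond the scatter) and lies beyond the scatter, while the only earlier step, a 1.5-fold lower number from compound 1 to compound 2 (0.17 log units; within the scatter) at a different position, stayed within it. So a change of a single heavy atom, one chlorine, is enough here to weaken inhibition by a clear margin, which the first two compounds gave no sign of. Nothing measured here accounts for this loss.

With only chloro shown at this position, it remains open whether the loss belongs to chloro itself or would also follow from another group in place of the hydrogen, such as fluoro, methyl or an amine. Going by these compounds, it is also open whether chloro at this position would give a similar step on the core of compound 2, which carries hydroxymethyl in place of one hydroxy group.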